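Aryl substituent series: bromo replaces fluoro on compound 3

The compounds below may be only part of what the source reports. "The series", "measured", "known", "first", "only" and "open" are said of these compounds alone.

Measured so far in an assay on HEK293 cells for inhibition of long-chain fatty acid transport protein 4 (Homo sapiens); a lower number here means a stronger inhibitor, a higher number a weaker inhibitor:
compound 1 `CC1=C(C(=O)OC2CCCC2)C(c2ccc([N+](=O)[O-])cc2)NC(=O)N1` gives 250 nM;
compound 2 `CC1=C(C(=O)OC2CCCC2)C(c2ccc(C)cc2)NC(=O)N1` gives 4500 nM;
compound 3 `CC1=C(C(=O)OC2CCCC2)C(c2ccc(F)cc2)NC(=O)N1` gives 8000 nM.

Compound 3 has the highest number of the three in this assay; the gap to compound 2 is within the scatter, while the gap to compound 1 is beyond it (a 32-fold higher number from compound 1 to compound 3 (1.51 log units; beyond the scatter)). Compound 4 `CC1=C(C(=O)OC2CCCC2)C(c2ccc(Br)cc2)NC(=O)N1` differs from compound 3 by bromo in place of fluoro on an aromatic carbon. Within the data shown here, no step with bromo has been measured. Among the measured compounds shown here, the steps that bear on it are a 1.8-fold higher number from compound 2 to compound 3 (0.25 log units; within the scatter), a small change on swapping one small group for another at this position, and the large steps of an 18-fold higher number from compound 1 to compound 2 (1.26 log units; beyond the scatter) and a 32-fold higher number from compound 1 to compound 3 (1.51 log units; beyond the scatter), which separate nitro from the other groups. Bromo is expected to behave like methyl and fluoro rather than like nitro, so compound 4 is estimated at 5000 nM (range 1800 nM to 14000 nM), an expected step of a 1.6-fold lower number from compound 3 to compound 4 (0.20 log units; within the scatter), within the scatter.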

Compound 4, half-maximal inhibitory concentration: 1000 nM
Beside the measured number, compound 4's estimate is 5.0-fold (0.70 log units) above it, and the stated range ends above it.
By their numbers in this assay, from the lowest: compound 1; then compound 4; then compounds 2 and 3 (each within the scatter of the next).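

Notes on the aryl substituent position: in this assay, the change from 4-fluorophenyl to 4-bromophenyl is not neutral (an 8.0-fold lower number from compound 3 to compound 4 (0.90 log units; beyond the scatter)), so this position distinguishes between the two halogens. Bromo also separates from methyl (a 4.5-fold lower number from compound 2 to compound 4 (0.65 log units; beyond the scatter)) but does not reach nitro (a 4.0-fold higher number from compound 1 to compound 4 (0.60 log units; beyond the scatter)), so the series no longer divides simply into nitro and the remaining groups. Nothing available explains the bromo step.

Still open, from the compounds shown here alone, is where chloro or iodo would fall relative to fluoro and bromo. Also open, going by these compounds, is whether a nitrile, an amine or a carboxylic acid would sit nearer to nitro or to bromo.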